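Propargylamine thioethers: swapping trifluoromethyl for methyl

The source may hold more compounds than are shown below. What is called first, only, known or untested is meant among the compounds shown, and "the series" means these compounds.

Two members of the series have been measured in an ADME assay on isolated protein for inhibition of Amine oxidase [flavin-containing] B (Homo sapiens); a higher number here means a weaker inhibitor, a lower number a stronger inhibitor. Compound 1 `C#CCNC1CCc2c(SCc3cccc(Br)c3)cccc21` returns only a limit of the assay, > 100000 nM, and no number. Among the compounds with values here, compound 2 `C#CCNC1CCc2c(SCc3ccc(C(F)(F)F)cc3)cccc21` gives 930 nM, which is the only actual number in hand. The other value, that of compound 1, is the limit (the limit of > 100000 nM in this assay, at which 1 of the 2 values shown sits). Nothing therefore connects a finished structural change to a measured shift, and no pattern can be drawn from this pair.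

Compound 3 `C#CCNC1CCc2c(SCc3ccc(C)cc3)cccc21` is the next candidate, differing from compound 2 by methyl in place of trifluoromethyl on an aromatic carbon. Within the data shown here, with no measured step of this kind to lean on, the expectation is a modest loss in this assay, though a result within the usual scatter of compound 2 would not surprise. The step expected from compound 2 to compound 3 is a 2.2-fold higher number from compound 2 to compound 3 (0.33 log units; beyond the scatter). Compound 3 is accordingly estimated at 2000 nM in this assay, with a range from 500 nM to 8000 nM.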

Compound 3, half-maximal inhibitory concentration: 320 nM
Compound 3: the middle estimate sits 6.3-fold (0.80 log units) above what was measured; the whole stated range lies above it.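

Within the data shown here, at this position, on an aromatic carbon para to a large group, methyl in place of trifluoromethyl gives a 2.9-fold lower number from compound 2 to compound 3 (0.46 log units; beyond the scatter) in this assay, so the group with fewer heavy atoms is the better of the two here. 4-methylphenyl in place of 3-bromophenyl gives an at least 310-fold lower number from compound 1 to compound 3 (2.49 log units; beyond the scatter), the largest step so far, though it changes both the group and where it sits. Compound 1 is a limit and not a number, so that step gives only a bound: the limit of > 100000 nM in this assay, at which 1 of the 3 values shown sits.

Going by these compounds, how much of the difference comes from bromine and how much from its place remains open; a 4-bromophenyl or 3-methylphenyl group would separate the two. On these data alone, whether methyl is itself favourable also remains open, and an unsubstituted phenyl, a chlorine or a methoxy group at the same place would test this.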